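A few compounds are considered here, and "the series" means these few. Any claim that something is new, unique, unknown or untested is made for them only; others in the source may bear on it.

Working notes on the series. Three compounds have numbers in an ADME assay on Caco-2 cells (Homo sapiens) for permeability, in the apical to basolateral direction; on this read-out higher numbers stand for higher permeability and lower numbers for lower permeability. Compound 1 `CCS(=O)(=O)N1CCC(CN(C2Cc3cc(C#N)ccc3N(Cc3cncn3C)C2)S(=O)(=O)c2ccccn2)CC1` gives 0.1 10^-6 cm/s, compound 2 `Cn1cncc1CN1CC(N(CC2CCN(C(=O)N3CCCC3)CC2)S(=O)(=O)c2ccccn2)Cc2cc(C#N)ccc21` gives 0.6 10^-6 cm/s, and compound 3 `Cn1cnc(S(=O)(=O)N(Cc2cccc(-n3cccc3)c2)C2Cc3cc(C#N)ccc3N(Cc3cncn3C)C2)c1` gives 0.2 10^-6 cm/s. Compound 2 stands highest of the three, with compound 3 nearest and compound 1 furthest, both gaps beyond the scatter. Going by the values given here, the only measured step that changes one place is a 6.0-fold higher number from compound 1 to compound 2 (0.78 log units; beyond the scatter), and it is the one sign of how the group on an amine nitrogen in a ring moves this assay. Compound 4 `CCNC(=O)N1CCC(CN(C2Cc3cc(C#N)ccc3N(Cc3cncn3C)C2)S(=O)(=O)c2ccccn2)CC1` alters the same region on a carbonyl carbon: ethylamino in place of pyrrolidin-1-yl on a carbonyl carbon. Among the compounds with values here, no measured pair sets an ethylamino against a pyrrolidin-1-yl, so the earlier step does not carry over directly; it shows only that changes at this end of the molecule have moved the number by a modest amount. The expected step for compound 4 is therefore small, a 1.5-fold lower number from compound 2 to compound 4 (0.18 log units; within the scatter), not clearly beyond the scatter and leaning to the lower side. Compound 4 is estimated at 0.4 10^-6 cm/s, with a range from 0.15 10^-6 cm/s to 1 10^-6 cm/s.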

Compound 4, apparent permeability: 0.6 10^-6 cm/s
Estimate against measurement, compound 4: 1.5-fold (0.18 log units) below, and the stated range covers the measured number.
By their numbers in this assay, from the lowest: compounds 1 and 3 (each within the scatter of the next); then compounds 2 and 4 (each within the scatter of the next).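

In this assay, ethylamino in place of pyrrolidin-1-yl on a carbonyl carbon gives no change at the digits printed from compound 2 to compound 4 (within the scatter), so at this place the ring can give way to the open chain, with its hydrogen-bond donor, and the number stays the same. Ethylcarbamoyl in place of ethylsulfonyl gives a 6.0-fold higher number from compound 1 to compound 4 (0.78 log units; beyond the scatter), the same size as a 6.0-fold higher number from compound 1 to compound 2 (0.78 log units; beyond the scatter), so the higher number relative to compound 1 does not depend on the pyrrolidin-1-yl ring and is seen with both carbonyl groups. No measurement available here gives a reason for either step.

From the compounds shown here alone, it remains open whether a longer chain, a morpholin-4-yl ring or a tertiary amine on the same carbonyl carbon would also leave the number in place. Going by these compounds, it is also open whether a simple acetyl group on the ring nitrogen would match the step away from ethylsulfonyl.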